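Replacing the carbamate on the aromatic nitrogen with an anilino group

A few compounds are considered here, and "the series" means these few. Any claim that something is new, unique, unknown or untested is made for them only; others in the source may bear on it.

The measured compounds:
compound 1, `CCCC(=O)Nc1nc2ccc(NC(=O)c3c(Cl)cccc3Cl)cc2s1`, 0.01 ug/mL
compound 2, `O=C(Nc1nc2ccc(NC(=O)c3c(Cl)cccc3Cl)cc2s1)OCc1ccccc1`, 0.018 ug/mL
compound 3, `O=C(Nc1nc2ccc(NC(=O)c3c(Cl)cccc3Cl)cc2s1)Oc1ccccc1`, 1.1 ug/mL

In a functional assay on WI-38 VA13 cells (Homo sapiens) for cytotoxicity (on this read-out higher numbers stand for an effect only at larger amounts of compound and lower numbers for an effect already at smaller amounts), compound 3 stands highest of the three; its nearest neighbour is compound 2 and its furthest is compound 1, and both gaps lie beyond the scatter. The steps that lead to compound 3 are large: a 110-fold higher number from compound 1 to compound 3 (2.04 log units; beyond the scatter) and a 61-fold higher number from compound 2 to compound 3 (1.79 log units; beyond the scatter), whereas a 1.8-fold higher number from compound 1 to compound 2 (0.26 log units; within the scatter) stays within the scatter.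

Compound 4, `COc1ccccc1Nc1nc2ccc(NC(=O)c3c(Cl)cccc3Cl)cc2s1`, differs from compound 3 in one place: 2-methoxyphenyl in place of phenoxycarbonyl on a nitrogen on an aromatic ring. Among the measured compounds shown here, the change removes the carbonyl-bearing group altogether, so no measured step mirrors it directly. What the three values show is that the two compounds carrying a carbonyl on that nitrogen give low numbers, while compound 3, with the phenoxycarbonyl, is the exception. Since compound 4 loses that exception-bearing group, a lower number is expected, though the size of the step is uncertain. The estimate for compound 4 in this assay is 0.2 ug/mL, with a range from 0.02 ug/mL to 2 ug/mL, which would mean an expected step of a 5.5-fold lower number from compound 3 to compound 4 (0.74 log units; beyond the scatter).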

Compound 4, half-maximal effective concentration: > 7.2 ug/mL
Compound 4: a limit, no number (the forecaster's own chance of this, stated with the estimate: 5%); middle value at least 36-fold (1.55 log units) away from the limit.
By their numbers in this assay, from the lowest: compounds 1 and 2 (each within the scatter of the next); then compound 3. At a limit, above all of these: compound 4.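

In this assay compound 4 gives a limit and not a number: the limit of > 7.2 ug/mL in this assay, at which 1 of the 4 values shown sits.

The exchange at this nitrogen on an aromatic ring gives an at least 6.5-fold higher number from compound 3 to compound 4 (0.81 log units; beyond the scatter), and the comparisons with the other two carbonyl-bearing compounds give an at least 400-fold higher number from compound 2 to compound 4 (2.60 log units; beyond the scatter) and an at least 720-fold higher number from compound 1 to compound 4 (2.85 log units; beyond the scatter). The earlier compounds shown here showed only that the read-out at this position could shift widely while a carbonyl stayed on the nitrogen, with compound 3 the one high case; compound 4 shows that 2-methoxyphenyl, with no carbonyl there, takes the read-out past all three, so within these four compounds the carbonyl-bearing groups on this nitrogen are the ones that give the lower numbers.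

Going by these compounds, how far past its limit compound 4 really lies remains open. So does whether the shift follows from losing the carbonyl or from the 2-methoxyphenyl group itself: a plain phenyl or a 2-methoxybenzoyl group on the same nitrogen would separate the two, and neither is among the compounds shown.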